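This account rests on a few compounds, and the source may have more. Where it says the series, first, only, none or still open, it means among the compounds named here.

Measured so far in an assay on HL-60 cells for agonist activity at vitamin D3 receptor (Homo sapiens), read by microscopy, with a stated time of 96 h; a higher number here means that more compound is needed for the effect, a lower number that less compound is needed:
compound 1 `CCn1c(C(=O)N(C)CCC#N)ccc1C(CC)(CC)c1ccc(OCC(=O)C(C)(C)C)c(C)c1` gives 9800 nM
compound 2 `CCn1c(C(=O)N(C)CCC#N)ccc1C(CC)(CC)c1ccc(OCC(O)C(C)(C)C)c(C)c1` gives 1960 nM
compound 3 `CC[C@@H](C)[C@H](NC(=O)c1ccc(C(CC)(CC)c2ccc(OCC(=O)C(C)(C)C)c(C)c2)n1CC)C(=O)O` gives 10 nM

Compound 2 stands second highest of these three numbers, separated from compound 1 by a 5.0-fold lower number from compound 1 to compound 2 (0.70 log units; beyond the scatter) and lying far above compound 3. Compound 4 `CCn1c(C(=O)Oc2ccc(CCO)cc2)ccc1C(CC)(CC)c1ccc(OCC(O)C(C)(C)C)c(C)c1` differs from compound 2 at one place only: a group of 10 heavy atoms (8 carbon, 2 oxygen; one six-membered aromatic ring of carbon only) in place of a group of 6 heavy atoms (4 carbon, 2 nitrogen; no ring), on a carbonyl carbon. A single measured step touches this same carbonyl carbon, a 980-fold lower number from compound 1 to compound 3 (2.99 log units; beyond the scatter), in which the (1-carboxy-2-methylbutyl)amino group entered. Compound 4 receives a different group there, one without that carboxylic acid, so that step gives only a rough guide, and a gain far smaller than it is expected, with the direction uncertain. For compound 4 the expected value in this assay is 700 nM, between 150 nM and 3500 nM, which means an estimated 2.8-fold lower number from compound 2 to compound 4 (0.45 log units; beyond the scatter).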

Compound 4, half-maximal effective concentration: 5100 nM
Beside the measured number, compound 4's estimate is 7.3-fold (0.86 log units) below it, and the stated range ends below it.
By their numbers in this assay, from the lowest: compound 3; then compound 2; then compounds 4 and 1 (each within the scatter of the next).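

At this carbonyl carbon, replacing (2-cyanoethyl)(methyl)amino with the larger group carrying a six-membered aromatic ring gives a 2.6-fold higher number from compound 2 to compound 4 (0.42 log units; beyond the scatter), a modest loss. A larger group here therefore does not by itself bring a gain like a 980-fold lower number from compound 1 to compound 3 (2.99 log units; beyond the scatter), which introduced a carboxylic acid. No available evidence explains the loss. Going by these compounds, it remains open whether a shorter carboxylic acid chain on an amine nitrogen at this carbonyl carbon would keep the low number of compound 3, and whether a simple methyl ester would behave like compound 4.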